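Ethoxy for benzylsulfanyl on the shared core

A few compounds are considered here, and "the series" means these few. Any claim that something is new, unique, unknown or untested is made for them only; others in the source may bear on it.

Measured so far in a functional assay on the whole organism for activation, with Mus musculus as the target; a higher number here means that more compound is needed for the effect, a lower number that less compound is needed:
compound 1 `CCSc1nc(N)c2nc(O)n(Cc3ccccc3)c2n1` gives 0.1 mg/kg
compound 2 `CCCCc1nc(N)c2nc(O)n(Cc3ccccc3)c2n1` gives 0.3 mg/kg
compound 3 `Nc1nc(SCc2ccccc2)nc2c1nc(O)n2Cc1ccccc1` gives > 1 mg/kg

The value of compound 3 is a limit of this assay, not a number, as noted in the limit of > 1 mg/kg in this assay, at which 1 of the 3 values shown sits. Compound 3 therefore sits at the weak end of the three: an at least 10-fold higher number from compound 1 to compound 3 (1.00 log units; beyond the scatter), and an at least 3.3-fold higher number from compound 2 to compound 3 (0.52 log units; beyond the scatter), both beyond the scatter, while a 3.0-fold higher number from compound 1 to compound 2 (0.48 log units; beyond the scatter) is the smaller change between the two compounds without a benzylsulfanyl group.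

Compound 4, `CCOc1nc(N)c2nc(O)n(Cc3ccccc3)c2n1`, has not yet been measured. It differs from compound 3 by ethoxy in place of benzylsulfanyl on an aromatic carbon. Both measured steps that lead into compound 3 exchange a small group for one carrying a six-membered aromatic ring, and both raise the number by a modest amount or more. Read in reverse, the step to compound 4 undoes that exchange, so a lower number is expected; the step is estimated as an at least 5.0-fold lower number from compound 3 to compound 4 (0.69 log units; beyond the scatter). Among the measured compounds shown here, the exchange of sulfur for oxygen in the link has no measured counterpart, which widens the range. Compound 4 is expected near 0.2 mg/kg, within 0.05 mg/kg to 1 mg/kg.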

Compound 4, minimum effective dose: 0.3 mg/kg
Compound 4: the middle estimate sits 1.5-fold (0.18 log units) below what was measured; the measured number falls inside the stated range.
By their numbers in this assay, from the lowest: compound 1; then compounds 2 and 4 (each within the scatter of the next). At a limit, above all of these: compound 3.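

In this assay, replacing the ring-bearing group on the aromatic carbon between two ring nitrogen atoms with ethoxy gives an at least 3.3-fold lower number from compound 3 to compound 4 (0.52 log units; beyond the scatter). Together with the low number of the ethylsulfanyl compound, this ties the high number to benzylsulfanyl rather than to a sulfur link as such. Ethoxy and butyl cannot be told apart, with no change at the digits printed from compound 2 to compound 4 (within the scatter), while the oxygen link does not match the sulfur link with the same ethyl chain, giving a 3.0-fold higher number from compound 1 to compound 4 (0.48 log units; beyond the scatter). The value of compound 3 is a limit and not a number: the limit of > 1 mg/kg in this assay, at which 1 of the 4 values shown sits.

Open, on these data alone, is whether the advantage of ethylsulfanyl over ethoxy and butyl holds for a longer chain on the sulfur, such as butylsulfanyl, which would also separate the effect of the aromatic ring in benzylsulfanyl from that of chain length alone. Also open, as far as these compounds go, is how a nitrogen link at this position, as in an ethylamino group, would compare with the sulfur and oxygen links on the shared core.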